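This account rests on a few compounds, and the source may have more. Where it says the series, first, only, none or still open, it means among the compounds named here.

The three measured compounds in an assay on MDA-MB-231 cells for binding affinity to C-X-C chemokine receptor type 4 (Homo sapiens), read by immunofluorescence and microscopy, with stated times of 10 min and 30 min; on this read-out lower numbers stand for an effect already at smaller amounts and higher numbers for an effect only at larger amounts of compound:

compound 1, `O=C(NCc1ccc(CNS(=O)(=O)c2ccccc2)cc1)c1ccncc1`, 10 nM
compound 2, `COc1ccccc1C(=O)NCc1ccc(CNS(=O)(=O)c2ccccc2)cc1`, 1 nM
compound 3, `Cc1ccc(C(=O)NCc2ccc(CNS(=O)(=O)c3ccccc3)cc2)cc1`, 100 nM

Compound 3 stands highest of the three numbers in this assay. Its nearest neighbour is compound 1, with a 10-fold higher number from compound 1 to compound 3 (1.00 log units; beyond the scatter), and its furthest is compound 2, with a 100-fold higher number from compound 2 to compound 3 (2.00 log units; beyond the scatter). Compound 4, `O=C(NCc1ccc(CNS(=O)(=O)c2ccccc2)cc1)c1cccc(F)c1`, has not yet been measured. It differs from compound 3 in one place: 3-fluorophenyl in place of 4-methylphenyl on a carbonyl carbon. Within the data shown here, no measured step exchanges these two groups directly. The two steps that involve the 4-methylphenyl group of compound 3 are a 10-fold higher number from compound 1 to compound 3 (1.00 log units; beyond the scatter) and a 100-fold higher number from compound 2 to compound 3 (2.00 log units; beyond the scatter), and both lie beyond the scatter, which shows that the group on the carbonyl carbon can shift the number substantially. With compound 3 already at the top and both comparable exchanges having moved the number, a downward step is expected, a 3.3-fold lower number from compound 3 to compound 4 (0.52 log units; beyond the scatter), though its size is poorly anchored. The expected value for compound 4 in this assay is 30 nM, with a range from 3 nM to 300 nM.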

Compound 4, effective concentration (reported as EC, without a stated level of effect): 100 nM
Compound 4: middle estimate off by 3.3-fold (0.52 log units), on the low side, within the range that was stated.
By their numbers in this assay, from the lowest: compound 2; then compound 1; then compounds 3 and 4 (each within the scatter of the next).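

In this assay, among these compounds, the exchange of 4-methylphenyl for 3-fluorophenyl on the carbonyl carbon brought no change at the digits printed from compound 3 to compound 4 (within the scatter), the first exchange at this position that did not move the number beyond the scatter. The gaps to the other two compounds are the same as those of compound 3, with a 100-fold higher number from compound 2 to compound 4 (2.00 log units; beyond the scatter) and a 10-fold higher number from compound 1 to compound 4 (1.00 log units; beyond the scatter), so these two substituted phenyl groups cannot be told apart here, while 2-methoxyphenyl and pyridin-4-yl each stand clearly apart from them. Nothing available accounts for this match between the two groups.

On these data alone, what a plain phenyl group, or a phenyl group carrying an amine or a carboxylic acid, would do on this carbonyl carbon stays open. So does whether 3-methoxyphenyl or 4-methoxyphenyl would keep the low number of compound 2.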